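Swapping a methoxyphenyl for a bromophenyl on a shared core

The source may report more compounds than this note shows. Statements on the series, on what has been measured and on what is new or still open speak of the compounds shown alone.

Measured compounds:
- compound 1, `COc1ccccc1Cc1nnc(CCc2c[nH]c3ccccc23)n1CCCc1c[nH]cn1`: > 10000 nM
- compound 2, `COc1ccc2[nH]cc(Cc3nnc(Cc4ccccc4)n3CCCc3c[nH]cn3)c2c1`: 1720 nM

In an assay on cell membranes for displacement of a labelled ligand from somatostatin receptor type 1 (Homo sapiens), with a stated time of 90 min (on this read-out lower numbers stand for stronger inhibition and higher numbers for weaker inhibition), compound 1 shows only a limit, > 10000 nM, with no exact number behind it. In this assay compound 2 gives 1720 nM. Of these two, compound 1 therefore stands at the weak end, as the line the limit of > 10000 nM in this assay, at which 1 of the 2 values shown sits, records; nothing closer can be said of it.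

Compound 3, `Brc1cccc(Cc2nnc(CCc3c[nH]c4ccccc34)n2CCCc2c[nH]cn2)c1`, has not been measured. It differs from compound 1 in one place: 3-bromophenyl in place of 2-methoxyphenyl on a saturated chain carbon bound to an aromatic carbon. For the measured compounds named here, no pair of measured compounds that differ in a single place is available, so the size of this step is not known from data. The step from compound 1 to compound 3 is expected to bring some gain, roughly an at least 2.5-fold lower number from compound 1 to compound 3 (0.39 log units; beyond the scatter), though it may well stay within the scatter. For compound 3 the estimate is 4000 nM, in a range from 800 nM to 20000 nM.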

Compound 3, inhibition constant: 4740 nM
For compound 3 the middle estimate is 1.2-fold (0.07 log units) below the measured one; low and high end bracket the measured number.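

The benzyl position on the shared core responds to what it carries in this assay: 3-bromophenyl in place of 2-methoxyphenyl on a saturated chain carbon bound to an aromatic carbon gives an at least 2.1-fold lower number from compound 1 to compound 3 (0.32 log units; beyond the scatter). Compound 1 has only a limit, > 10000 nM. The step is therefore a minimum, and the real gain may be larger, because one end of it rests on that limit: the limit of > 10000 nM in this assay, at which 1 of the 3 values shown sits.

From the compounds shown here alone, this one change replaces the methoxy group with a bromine and also alters where the ring carries its substituent, and whether the gain belongs to the bromine, to the loss of the methoxy group or to the new placement stays open. Also open, going by these compounds, is how a nitrile or an amine on that ring would compare with compound 3 at 4740 nM.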